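This account rests on a few compounds, and the source may have more. Where it says the series, first, only, none or still open, it means among the compounds named here.

Measured so far in a physicochemical assay for lipophilicity, using the shake flask method, in phosphate buffer, measured as octanol-water partition, with a stated time of 85 min, at pH 7.4; a lower number here means a more polar compound, a higher number a more lipophilic compound:
compound 1 `c1cn2cc(-c3ccsc3)nc(-c3ccc4ncn(C5CCCCC5)c4c3)c2n1`, 1.81
compound 2 `CCc1ccc(-c2cn3ccnc3c(-c3ccc4ncn(C5CCCCC5)c4c3)n2)cc1`, 1.66
compound 3 `CC(=O)c1ccc(-c2cn3ccnc3c(-c3ccc4ncn(C5CCCCC5)c4c3)n2)cc1`, 2.06

Compound 1 stands second highest of the three numbers; compound 2 is nearest, a number 0.15 log units lower from compound 1 to compound 2 (within the scatter), and compound 3 furthest, a number 0.25 log units higher from compound 1 to compound 3 (within the scatter). Between compound 2 and compound 3 the only step beyond the scatter is a number 0.40 log units higher from compound 2 to compound 3 (beyond the scatter). Compound 4 `Clc1ccc(-c2cn3ccnc3c(-c3ccc4ncn(C5CCCCC5)c4c3)n2)cc1` differs from compound 1 in one place: 4-chlorophenyl in place of thiophen-3-yl on an aromatic carbon. The two steps that replace thiophen-3-yl on that carbon, a number 0.15 log units lower from compound 1 to compound 2 (within the scatter) and a number 0.25 log units higher from compound 1 to compound 3 (within the scatter), both stayed within the scatter, so for this assay a step of at most modest size is expected, if anything upward. The expected step is a number 0.14 log units higher from compound 1 to compound 4 (within the scatter). Compound 4 is estimated at 1.95, range 1.6 to 2.3.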

Compound 4, partition coefficient: 1.51
Compound 4: middle estimate off by 0.44 log units, on the high side; the whole stated range lies above it.
By their numbers in this assay, from the lowest: compounds 4, 2, 1 and 3 (each within the scatter of the next, the first and the last beyond it).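

In this assay, a third replacement of thiophen-3-yl again stays within the scatter, with 4-chlorophenyl giving a number 0.30 log units lower from compound 1 to compound 4 (within the scatter). On the phenyl ring, chloro is not separated from ethyl, a number 0.15 log units lower from compound 2 to compound 4 (within the scatter), but it is separated from acetyl, a number 0.55 log units lower from compound 3 to compound 4 (beyond the scatter), so compound 3 now stands beyond the scatter from both of these analogues, though not from compound 1. Nothing available explains these steps. 

Still open, from the compounds shown here alone, is whether an amine or a carboxylic acid in place of chloro would move the partition coefficient further from compound 4. Also open, going by these compounds, is whether a longer chain in place of ethyl would remain within the scatter of compound 2.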